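Chain Length and Cytotoxicity in a Carbamate Series

The source may hold more compounds than are shown below. What is called first, only, known or untested is meant among the compounds shown, and "the series" means these compounds.

Three compounds share one core, a carbamate carrying three carboxylic acid arms, and differ only in the length of the saturated chain on the carbamate oxygen. Compound 1 `CCCCCCCCCCCCCCCCCCCCCCOC(=O)NC(CCC(=O)O)(CCC(=O)O)CCC(=O)O` is the longest of them; in an ADME assay on cells (Epithelial cell, Homo sapiens) for cytotoxicity, read by MTT assay (a higher number here means that more compound is needed for the effect, a lower number that less compound is needed), compound 1 gives 360000 nM. Compound 2 `CCCCCCCCCCCCCCCCOC(=O)NC(CCC(=O)O)(CCC(=O)O)CCC(=O)O` has the shortest chain, and in this assay compound 2 gives 440000 nM. Compound 3 `CCCCCCCCCCCCCCCCCCOC(=O)NC(CCC(=O)O)(CCC(=O)O)CCC(=O)O` lies between them in chain length, and in this assay compound 3 gives 350000 nM.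

The steps of a 1.0-fold lower number from compound 1 to compound 3 (0.01 log units; within the scatter) and a 1.3-fold lower number from compound 2 to compound 3 (0.10 log units; within the scatter) both fall within the scatter, as does a 1.2-fold higher number from compound 1 to compound 2 (0.09 log units; within the scatter), so compound 3 stands level with both neighbours: across this series, shortening or lengthening the chain has left the number essentially unchanged.

Compound 4 `CCCCCCCCCCCCCCCCCCCCOC(=O)NC(CCC(=O)O)(CCC(=O)O)CCC(=O)O` extends the chain of compound 3 by ethyl in place of hydrogen on a saturated chain carbon, ten or more bonds along the chain from an oxygen next to a carbonyl group. Because a 1.3-fold lower number from compound 2 to compound 3 (0.10 log units; within the scatter) and a 1.0-fold lower number from compound 1 to compound 3 (0.01 log units; within the scatter) were both within the scatter, no step beyond the scatter is expected for this change, and a 1.1-fold higher number from compound 3 to compound 4 (0.02 log units; within the scatter) is the estimated outcome. In this assay compound 4 is expected to give 370000 nM, with a range from 250000 nM to 550000 nM.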

Compound 4, half-maximal effective concentration: 280000 nM
The estimate for compound 4 lay 1.3-fold (0.12 log units) above the measured number, within the range that was stated.
By their numbers in this assay, from the lowest: compounds 4, 3, 1 and 2 (each within the scatter of the next).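

All three new steps stay within the scatter in this assay: a 1.3-fold lower number from compound 3 to compound 4 (0.10 log units; within the scatter), a 1.6-fold lower number from compound 2 to compound 4 (0.20 log units; within the scatter) and a 1.3-fold lower number from compound 1 to compound 4 (0.11 log units; within the scatter). Even butyl in place of hydrogen, the largest change among these steps, does not move the number beyond the scatter at this position, on a saturated chain carbon. Ethyl in place of hydrogen also reads alike on two starting compounds, with the two steps no further apart than the scatter allows: the same change on two cores in this assay, a 1.3-fold lower number (0.10 log units; within the scatter) from compound 2 to compound 3 and a 1.3-fold higher number (0.11 log units; within the scatter) from compound 4 to compound 1, 1.6-fold (0.21 log units) apart, within the scatter of two such steps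

The compounds shown leave open whether a chain much shorter than that of compound 2, such as hexyl, or a chain ending in an amine would behave the same way. They also leave open what happens when the three carboxylic acid arms of the shared core are replaced by esters.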